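Ethyl for methoxy at the pendant aryl ring

This account rests on a few compounds, and the source may have more. Where it says the series, first, only, none or still open, it means among the compounds named here.

Compound 3 `COc1ccc(-c2cc(Cl)cc(C(=O)Nc3nn[nH]n3)n2)cc1` stands highest of the three compounds measured in a functional assay on the whole organism with Rattus norvegicus as the target, at a dose of 3 mg/kg by the oral route (on this read-out higher numbers stand for a stronger effect at the one dose given and lower numbers for a weaker effect), where compound 3 gives 100%. Compound 2 `COc1cccc(-c2cc(Cl)cc(C(=O)Nc3nn[nH]n3)n2)c1` lies within the scatter of that number, since in this assay compound 2 gives 95%. For the measured compounds named here, compound 1 `O=C(Nc1nn[nH]n1)c1cc(Cl)cc(-c2ccc(Cl)cc2)n1` is far below: in this assay compound 1 gives 11%, and the only single change measured, methoxy in place of chloro on an aromatic carbon, gave a number 89 percentage points higher from compound 1 to compound 3 (beyond the scatter).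

Compound 4 `CCc1ccc(-c2cc(Cl)cc(C(=O)Nc3nn[nH]n3)n2)cc1` differs from compound 3 by ethyl in place of methoxy on an aromatic carbon. Going by the values given here, no measured step exchanges methoxy for ethyl, so the one recorded step bears on it only indirectly: it shows that the group on that aromatic carbon can move this read-out a great deal. Because compound 3 gives 100% and compound 2 gives 95%, a high number is expected to persist, with an estimated a number 15 percentage points lower from compound 3 to compound 4 (beyond the scatter) allowing for a drop. Compound 4 is therefore estimated at 85%, in a range from 45% to 100%.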

Compound 4, a percentage reported as inhibition, in the whole organism at one dose (the size of the read-out at that dose, not a potency): 100%
Estimate against measurement, compound 4: 15 percentage points below; measured number inside the range.
By their numbers in this assay, from the lowest: compound 1; then compounds 2, 3 and 4 (each within the scatter of the next).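

In this assay, replacing methoxy with ethyl on this aromatic carbon gives no change at the digits printed from compound 3 to compound 4 (within the scatter), so among these compounds the high number does not depend on the oxygen or the hydrogen-bond acceptor that leaves with methoxy. For the compounds shown here, replacing chloro with ethyl at the same place gives a number 89 percentage points higher from compound 1 to compound 4 (beyond the scatter), which leaves chloro as the only one of the three groups tested here that goes with a low number. No measurement given here accounts for that difference.

Both high numbers come from a single dose, so they do not show whether methoxy and ethyl differ in potency. The compounds shown also leave open whether a longer chain such as propyl, an amine or a carboxylic acid on this carbon would keep the number high or bring it down towards that of compound 1.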